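The source may hold more compounds than are shown below. What is called first, only, known or untested is meant among the compounds shown, and "the series" means these compounds.

Two compounds of the series have been run so far. Compound 1 `[O-][n+]1ccc2c(c1)ncn2[C@H]1C[C@H](O)[C@@H](CO)O1` gives 0% in a functional assay (Homo sapiens) for inhibition of Nucleic Acid, tested at 100 uM; on this read-out lower numbers stand for less inhibition and higher numbers for more inhibition at the one concentration tested (going by the name of the read-out). Compound 2 `OC[C@H]1OC(n2cnc3c(NCc4ccccc4)nccc32)[C@H](O)[C@@H]1O` gives 32% in this assay, which places it highest of the two numbers; its nearest neighbour is compound 1, whose number lies beyond the scatter below it. Among the measured compounds shown here, no pair of measured compounds differs in one place only, so no single step can be read off directly.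

Compound 3 `OCCNc1nccc2c1ncn2C1O[C@H](CO)[C@@H](O)[C@H]1O` is the next candidate. It keeps the shared core and sugar of compound 2 and differs in one place: hydroxymethyl in place of phenyl on a saturated chain carbon bound to a nitrogen on an aromatic ring

With only the two values above to go on, the step from compound 2 to compound 3 in this assay is expected to be a moderate one downward, a number 17 percentage points lower from compound 2 to compound 3 (beyond the scatter), since compound 2 at 32% is the only read-out carrying the benzyl group, while compound 1 gives 0%. Compound 3 is therefore estimated at 15%, within 0% to 35%.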

Compound 3, a percentage reported as inhibition, at one concentration (the size of the read-out at that concentration, not a potency): 0%
Compound 3: middle estimate off by 15 percentage points, on the high side, within the range that was stated.
By their numbers in this assay, from the lowest: compounds 1 and 3 (each within the scatter of the next); then compound 2.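

In this assay, hydroxymethyl in place of phenyl on a saturated chain carbon bound to a nitrogen on an aromatic ring gives a number 32 percentage points lower from compound 2 to compound 3 (beyond the scatter) for a change at one place only. Among the compounds shown here, with the shared core and sugar held, this is the first direct sign that the read-out depends on the group at this position. The inhibition seen with the benzylamino group does not persist with the (2-hydroxyethyl)amino group. Nothing available explains the size of this step.

For the compounds shown here, the single step changes ring, chain and hydroxyl together, so their separate contributions remain unresolved. A cyclohexylmethyl group, a plain propyl chain or a 2-phenylethyl group at this position would begin to separate them.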